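The source may hold more compounds than are shown below. What is called first, only, known or untested is meant among the compounds shown, and "the series" means these compounds.

The measured compounds:

Compound 1, `O=S(=O)(NC[C@H]1CC[C@H](CNC2CCc3cc(F)ccc3C2Cc2cccnc2)CC1)c1ccccc1F`, gives 19 nM in an assay on HEK293 cells for binding affinity to Neuropeptide Y receptor type 5 (Homo sapiens); on this read-out lower numbers stand for stronger inhibition and higher numbers for weaker inhibition.
Compound 2, `O=S(=O)(NC[C@H]1CC[C@H](CNC2CCc3cc(O)ccc3C2Cc2cccnc2)CC1)c1ccccc1F`, gives 7 nM in this assay.
Compound 3, `C=CCC1c2ccc(F)cc2CCC1NC[C@H]1CC[C@H](CNS(=O)(=O)c2ccccc2)CC1`, gives 21 nM in this assay.

Compounds 1 and 2 share a core and differ in one place: hydroxy in place of fluoro on an aromatic carbon. This change gave a 2.7-fold lower number from compound 1 to compound 2 (0.43 log units; beyond the scatter), a step that lies beyond the usual scatter of the assay but remains modest in size.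

Compound 3 is built on a different core. The difference between the core of compound 3 and the core of compound 1 is not broken down here. Their values in this assay lie within the scatter of each other, so nothing can be said about which of the two is the stronger binder; compound 2 is the only one of the three whose number stands apart from the other two beyond the scatter.

The unmeasured compound 4, `C=CCC1c2ccc(O)cc2CCC1NC[C@H]1CC[C@H](CNS(=O)(=O)c2ccccc2)CC1`, is related to compound 3 in the same way that compound 2 is related to compound 1: hydroxy in place of fluoro on an aromatic carbon. The place of the change is described in identical words for both pairs, so this is the same change made on a second core.

For the measured compounds named here, on the single precedent, compound 4 is expected to improve on compound 3 by about a 2.6-fold lower number from compound 3 to compound 4 (0.42 log units; beyond the scatter), resting on the step of a 2.7-fold lower number from compound 1 to compound 2 (0.43 log units; beyond the scatter) seen when the same change was made on the core of compound 1. Because compound 3 gives 21 nM, compound 4 is estimated at 8 nM in this assay, with a likely range of 4 nM to 18 nM, the width allowing for the chance that the change carries less well onto the second core.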

Compound 4, half-maximal inhibitory concentration: 5 nM
For compound 4 the middle estimate is 1.6-fold (0.20 log units) above the measured one, within the range that was stated.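

Putting hydroxy in place of fluoro on an aromatic carbon gave a 4.2-fold lower number from compound 3 to compound 4 (0.62 log units; beyond the scatter) in this assay, so on the core of compound 3 the number fell, as it had on the core of compound 1. The two steps point the same way and cannot be told apart in size, so the larger figure on the second core should not be read as a larger gain: the same change on two cores in this assay, a 2.7-fold lower number (0.43 log units; beyond the scatter) from compound 1 to compound 2 and a 4.2-fold lower number (0.62 log units; beyond the scatter) from compound 3 to compound 4, 1.5-fold (0.19 log units) apart, within the scatter of two such steps. This shows that the change carried across these two cores in this assay, but two pairs do not establish a rule for the series, and they do not show why the number falls or which features of a core allow the change to carry.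

The aromatic carbon bears only fluoro or hydroxy in the compounds shown, so they leave open whether the gain is particular to hydroxy or would also appear with methoxy, an amine or a plain hydrogen at that place. They also leave open whether the change would carry onto a third core, for instance one with a longer chain in place of the allyl group of compound 4.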